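Pentafluorosulfanyl anilides: moving the trifluoromethyl on the sulfonyl ring

The compounds below may be only part of what the source reports. "The series", "measured", "known", "first", "only" and "open" are said of these compounds alone.

Compound 1 `CC(O)(CS(=O)(=O)c1cccc(C(F)(F)F)c1)C(=O)Nc1ccc(S(F)(F)(F)(F)F)cc1`: 21000 nM
Compound 2 `CC(O)(CS(=O)(=O)c1ccccc1C(F)(F)F)C(=O)Nc1ccc(S(F)(F)(F)(F)F)cc1`: 10800 nM
Compound 3 `CC(O)(CS(=O)(=O)c1cccc(C(F)(F)F)c1)C(=O)Nc1cccc(S(F)(F)(F)(F)F)c1`: 21800 nM

Of the compounds shown here, three have been measured in a functional assay on LNCaP cells (Homo sapiens) for antiproliferative activity, read by propidium iodide staining, with a stated time of 96 h; a higher number here means a weaker inhibitor, a lower number a stronger inhibitor. In this assay compound 1 gives 21000 nM and compound 2 gives 10800 nM. The two differ in one place, (2-(trifluoromethyl)phenyl in place of 3-(trifluoromethyl)phenyl on a sulfonyl sulfur), and the step is a 1.9-fold lower number from compound 1 to compound 2 (0.29 log units; within the scatter). Compound 3 gives 21800 nM in this assay. It shares the change-bearing sulfonyl ring with compound 1, but the difference between the two cores is not broken down here; the two values lie within the usual scatter of each other. Against compound 2 the value of compound 3 stands beyond the scatter, the number of compound 2 being the lower of the two.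

Compound 4 `CC(O)(CS(=O)(=O)c1ccccc1C(F)(F)F)C(=O)Nc1cccc(S(F)(F)(F)(F)F)c1` has not been measured. It arises from compound 3 by 2-(trifluoromethyl)phenyl in place of 3-(trifluoromethyl)phenyl on a sulfonyl sulfur, the same change, made at the same kind of place, that turns compound 1 into compound 2. Because that change gave a 1.9-fold lower number from compound 1 to compound 2 (0.29 log units; within the scatter), a step of a similar size is expected here, and it is estimated as a 1.9-fold lower number from compound 3 to compound 4 (0.28 log units; within the scatter). The expectation rests on a single measured pair and on the two cores not being compared in a counted way, so it is held loosely. Compound 4 is estimated at 11500 nM in this assay, with a range from 5500 nM to 25000 nM.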

Compound 4, half-maximal inhibitory concentration: 24900 nM
Estimate against measurement, compound 4: 2.2-fold (0.34 log units) below; low and high end bracket the measured number.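

On the core of compound 3, putting 2-(trifluoromethyl)phenyl in place of 3-(trifluoromethyl)phenyl on a sulfonyl sulfur gave, in this assay, a 1.1-fold higher number from compound 3 to compound 4 (0.06 log units; within the scatter). Set beside the same change on the core of compound 1, the two steps point in opposite directions on paper, yet the gap between them does not stand out from the noise: the same change on two cores in this assay, a 1.9-fold lower number (0.29 log units; within the scatter) from compound 1 to compound 2 and a 1.1-fold higher number (0.06 log units; within the scatter) from compound 3 to compound 4, 2.2-fold (0.35 log units) apart, within the scatter of two such steps. What this shows is that on neither core did the change produce a step beyond the scatter, and that the two cores cannot be told apart in their response to it; it does not show that the change has a real effect of either sign, that the core alters its outcome, or that the same would hold on any core beyond these two.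

The compounds shown leave open how the series responds to a group other than trifluoromethyl on the sulfonyl ring, such as a nitrile or a methoxy group, since only two placements of that one group appear here. They also leave open what follows when the pentafluorosulfanyl group on the anilide ring gives way to a group such as a nitrile, or when the sulfonyl gives way to a thioether.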